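The compounds below may be only part of what the source reports. "The series", "measured", "known", "first", "only" and "open" are said of these compounds alone.

Three compounds that share one core have been measured in a functional assay on NB-4 cells (Homo sapiens) for cytotoxicity, read by CCK-8 assay, with a stated time of 24 h; on this read-out higher numbers stand for weaker inhibition and lower numbers for stronger inhibition:

Compound 1 `C=CC(=O)N1C(=O)CC(c2ccc([N+](=O)[O-])cc2)Sc2ccccc21`: 37700 nM
Compound 2 `C=CC(=O)N1C(=O)CC(c2cccc(Cl)c2)Sc2ccccc21`: 31700 nM
Compound 3 `C=CC(=O)N1C(=O)CC(c2ccc(C(F)(F)F)cc2)Sc2ccccc21`: 38600 nM

Compound 1 stands second highest of the three numbers. Its nearest neighbour is compound 3, separated by a 1.0-fold higher number from compound 1 to compound 3 (0.01 log units; within the scatter), and the gap between compound 1 and compound 2 is also within the scatter, so the three values cannot be put in any order. The unmeasured compound 4 `C=CC(=O)N1C(=O)CC(c2ccccc2)Sc2ccccc21` differs from compound 1 by hydrogen in place of nitro on an aromatic carbon. Among the compounds with values here, only one measured step speaks to this change, the exchange of one group on that aromatic carbon for another in going from compound 1 to compound 3, and it stayed within the scatter. A step removing the group altogether has not been seen, so the expectation for compound 4 can only be that it stays close to compound 1, with no step beyond the scatter in this assay. The expected step is a 1.0-fold lower number from compound 1 to compound 4 (0.02 log units; within the scatter). For compound 4 the estimate is 36000 nM, with a range from 18000 nM to 72000 nM.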

Compound 4, half-maximal inhibitory concentration: 35500 nM
Compound 4: middle estimate off by 1.0-fold (0.01 log units), on the high side; measured number inside the range.
By their numbers in this assay, from the lowest: compounds 2, 4, 1 and 3 (each within the scatter of the next).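

Until now, the compounds in this assay only exchanged one group for another on the aromatic ring, whereas compound 4 shows that ring with no such group at all. Hydrogen in place of nitro gives a 1.1-fold lower number from compound 1 to compound 4 (0.03 log units; within the scatter), hydrogen in place of trifluoromethyl gives a 1.1-fold lower number from compound 3 to compound 4 (0.04 log units; within the scatter), and hydrogen in place of chloro gives a 1.1-fold higher number from compound 2 to compound 4 (0.05 log units; within the scatter). In these four compounds, then, the read-out does not separate a ring bearing one of these three groups from a ring bearing only hydrogen, and no further evidence bears on the reason for this.

Going by these compounds, whether an amine, a carboxylic acid or a longer chain on this ring would give a step beyond the scatter remains open. So does the effect of any change elsewhere on the shared core.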